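This account rests on a few compounds, and the source may have more. Where it says the series, first, only, none or still open, it means among the compounds named here.

Measured compounds:
- Compound 1, `Cc1ccc(-n2nccn2)c(C(=O)N2C[C@H](C#Cc3ccc(CO)cn3)CC[C@H]2C)c1`: 130 nM
- Compound 2, `Cc1ccc(-n2nccn2)c(C(=O)N2C[C@H](C#Cc3cnccc3O)CC[C@H]2C)c1`: 7.5 nM

Both compounds were tested in an assay on cells for binding affinity to Orexin receptor type 2 (Homo sapiens), read by radioligand binding; a lower number here means a stronger inhibitor, a higher number a weaker inhibitor. Compound 1 gives 130 nM, and compound 2 gives 7.5 nM. For the measured compounds named here, compound 2 therefore holds the lowest of the two numbers, and its only neighbour is compound 1, reached by a 17-fold lower number from compound 1 to compound 2 (1.24 log units; beyond the scatter). Going by the values given here, that single step swaps the whole group on the triple-bonded carbon and is the only piece of evidence on how this assay responds to changes at that end of the molecule.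

Compound 3, `Cc1ccc(-n2nccn2)c(C(=O)N2C[C@H](C#Cc3cccnc3O)CC[C@H]2C)c1`, has not yet been measured. It differs from compound 2 only in where the hydroxyl sits on the pyridine ring: 2-hydroxypyridin-3-yl in place of 4-hydroxypyridin-3-yl on a triple-bonded carbon. Among the compounds with values here, no measured step covers this kind of rearrangement, so the expectation must rest on the general observation that the step from compound 1 to compound 2 was large, which shows that the identity of this group matters a great deal in this assay.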

Compound 3, inhibition constant: 24 nM
The estimate for compound 3 lay 1.0-fold (0.02 log units) above the measured number; the range from low to high includes it.
By their numbers in this assay, from the lowest: compound 2; then compound 3; then compound 1.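

In this assay, the hydroxyl and the ring nitrogen change places on the pyridine while the atoms and the counts of hydrogen-bond donors and acceptors stay the same, yet the result is a 3.2-fold higher number from compound 2 to compound 3 (0.51 log units; beyond the scatter). The earlier step replaced the whole group on the triple-bonded carbon, so this one adds something new: the arrangement within the ring matters on its own, and 2-hydroxypyridin-3-yl still compares well with 5-(hydroxymethyl)pyridin-2-yl, giving a 5.4-fold lower number from compound 1 to compound 3 (0.73 log units; beyond the scatter). Nothing available explains why one arrangement gives a lower number than the other.

The three compounds leave open whether the hydroxyl itself is needed for these lower numbers, a question that a methoxy group or an amino group in its place on the same pyridine ring would help to answer. They also leave open how a 5-hydroxypyridin-3-yl group on the triple-bonded carbon would compare, which would show whether other arrangements of the same atoms give a number closer to that of compound 2 or of compound 3.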